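Metabolic stability across a bicyclic amide series

The source may hold more compounds than are shown below. What is called first, only, known or untested is meant among the compounds shown, and "the series" means these compounds.

Within the data shown here, compound 3 `O=C(NCc1ccc(S(=O)(=O)c2ccccc2)cc1)c1ccc2nncn2c1` stands highest of the two numbers so far in an ADME assay on microsomes from liver (Mus musculus) for metabolic stability, read by LC-MS, with a stated time of 30 min, tested at 1 uM (a lower number here means that less of the compound is left, a higher number that more of the compound is left), where compound 3 gives 47%. Compound 2 `O=C(NCc1ccc(S(=O)(=O)N2CCCCC2)cc1)c1ccn2cncc2c1` gives 1% in this assay, a number far lower than that of compound 3 and beyond the scatter. Compound 1 `O=C(NCc1ccc(S(=O)(=O)N2CCCCC2)cc1)c1cc2cnccc2s1` gives "below limit of detection" (no number reported) in this assay, so no number stands for compound 1. Among the measured compounds shown here, no single-point step between measured compounds is available, so the two numbers alone describe the spread.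

Compound 4 `O=C(NCc1ccc(S(=O)(=O)c2ccccc2)cc1)c1cc2cnccc2[nH]1` differs from compound 3 by a group of 9 heavy atoms (7 carbon, 2 nitrogen; one five-membered aromatic ring with 1 hetero atom, one six-membered aromatic ring with 1 hetero atom) in place of a group of 9 heavy atoms (6 carbon, 3 nitrogen; one five-membered aromatic ring with 3 hetero atoms, one six-membered aromatic ring with 1 hetero atom), on a carbonyl carbon. Compounds 1 and 2 show that the other ring pairs of this series sit at the low end, so a downward step is expected for compound 4, estimated as a number 27 percentage points lower from compound 3 to compound 4 (beyond the scatter). Compound 4 is expected to give 20% in this assay, within 3% to 45%.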

Compound 4, percent of the compound remaining: 54%
Compound 4: middle estimate off by 34 percentage points, on the low side; the whole stated range lies below it.
By their numbers in this assay, from the lowest: compound 2; then compounds 3 and 4 (each within the scatter of the next).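

On the carbonyl carbon, the exchange of rings gives a number 7 percentage points higher from compound 3 to compound 4 (within the scatter) in this assay, so the group with 1 hetero atom in its five-membered aromatic ring and 1 hydrogen-bond donor is tolerated as well as the group with 3 hetero atoms there. Compounds 1 and 2 differ from compounds 3 and 4 in more than one place, so their low readings cannot be assigned to the ring pair alone. Nothing at hand explains why the two groups read alike.

Open, from the compounds shown here alone, is whether this tolerance holds with the other sulfonyl group of compounds 1 and 2. Also open, going by these compounds, is how a methyl group or a fluorine on the entering group would read.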